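Two Aryl Replacements on a Shared Piperazine Core

A few compounds are considered here, and "the series" means these few. Any claim that something is new, unique, unknown or untested is made for them only; others in the source may bear on it.

Compound 1 `Nc1scc(CN2CCN(c3ccc([N+](=O)[O-])cc3)CC2)c1C(=O)c1ccc(Cl)cc1`: 1%
Compound 2 `Nc1scc(CN2CCN(c3ccncc3)CC2)c1C(=O)c1ccc(Cl)cc1`: 1%

In an assay on CHO cells for displacement of a labelled ligand from adenosine receptor A1 (Homo sapiens), read by scintillation counting, with a stated time of 120 min, tested at 10 uM (on this read-out higher numbers stand for more inhibition at the one concentration tested (going by the name of the read-out) and lower numbers for less inhibition), compound 1 gives 1% and compound 2 gives 1%. Going by the values given here, compound 1 therefore stands level with compound 2 within the scatter, and the one measured step, no change at the digits printed from compound 1 to compound 2 (within the scatter), also replaces the 4-nitrophenyl on the ring nitrogen. Compound 3 `Nc1scc(CN2CCN(c3cccc(Cl)c3)CC2)c1C(=O)c1ccc(Cl)cc1` differs from compound 1 in one place: 3-chlorophenyl in place of 4-nitrophenyl on an amine nitrogen in a ring. Among the compounds with values here, since the only comparable step showed no change, no step beyond the scatter is expected here either. Compound 3 is therefore estimated at 2%, with a range from -8% to 12%, which means an expected step of a number 1 percentage points higher from compound 1 to compound 3 (within the scatter).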

Compound 3, a percentage reported as inhibition, at one concentration (the size of the read-out at that concentration, not a potency): 0%
Beside the measured number, compound 3's estimate is 2 percentage points above it; measured number inside the range.
By their numbers in this assay, from the lowest: compounds 3, 1 and 2 (each within the scatter of the next).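

In this assay, 3-chlorophenyl on the amine nitrogen in the ring gives a third group here, with the steps (a number 1 percentage points lower from compound 1 to compound 3 (within the scatter)) and (a number 1 percentage points lower from compound 2 to compound 3 (within the scatter)). All three aromatic groups at this place, including the one that carries chlorine, therefore lie within the scatter of each other, so the earlier lack of change now extends across three groups. Nothing available explains this result.

Still open, on these data alone, is whether a longer chain, an amine or a carboxylic acid at this nitrogen would give a different reading. The three compounds also leave open whether changes elsewhere on the shared core would do so.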